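The source may hold more compounds than are shown below. What is called first, only, known or untested is meant among the compounds shown, and "the series" means these compounds.

Of the compounds shown here, two have numbers so far. For the measured compounds named here, in a functional assay on NCI-H460 cells (Homo sapiens) for cytotoxicity, read by MTT assay, with a stated time of 72 h (on this read-out lower numbers stand for stronger inhibition and higher numbers for weaker inhibition), compound 1 (`CN(C)Cc1ccc2nc(NC(=O)N/N=C3\C(=O)Nc4ccc(Cl)cc43)sc2c1`) gives 1170 nM and compound 2 (`CN(C)Cc1ccc2nc(NC(=O)N/N=C3\C(=O)Nc4ccc(F)cc43)sc2c1`) gives 1550 nM on the same read-out, so compound 2 stands within the scatter of the only other measured compound. Compound 3 (`CC1CCN(Cc2ccc3nc(NC(=O)N/N=C4\C(=O)Nc5ccc(F)cc54)sc3c2)CC1`) keeps the fluoro of compound 2 and changes one group: 4-methylpiperidin-1-yl in place of dimethylamino on a saturated chain carbon bound to an aromatic carbon is the whole difference, with 4-methylpiperidin-1-yl in place of dimethylamino on a saturated chain carbon bound to an aromatic carbon.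

Going by the values given here, the only measured step (a 1.3-fold higher number from compound 1 to compound 2 (0.12 log units; within the scatter)) is fluoro in place of chloro on an aromatic carbon and lies within the scatter. It sits at a different place in the structure, so it offers neither a size nor a direction for the present change. Among the compounds with values here, no measured compound here varies the dimethylamino group. In this assay the working expectation is therefore no step beyond the scatter, held with wide uncertainty. The expected step is a 1.3-fold lower number from compound 2 to compound 3 (0.11 log units; within the scatter) and rests on little data. For compound 3 the estimated value is 1200 nM with an expected range from 400 nM to 3500 nM in this read-out.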

Compound 3, half-maximal inhibitory concentration: 1430 nM
Estimate against measurement, compound 3: 1.2-fold (0.08 log units) below; measured number inside the range.
By their numbers in this assay, from the lowest: compounds 1, 3 and 2 (each within the scatter of the next).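

In this assay, the replacement at the saturated chain carbon bound to an aromatic carbon gives a 1.1-fold lower number from compound 2 to compound 3 (0.03 log units; within the scatter), the first step read at this place in the structure. The group entering here has 7 heavy atoms and one six-membered non-aromatic ring, against 3 heavy atoms and no ring in dimethylamino, and this difference produces no step beyond the scatter on this read-out. Compound 1 and compound 2 could not show this, since they differ only in chloro and fluoro on an aromatic carbon, and no evidence at hand bears on this result.

The compounds shown leave open whether the same holds for amines of another kind at this place, such as morpholin-4-yl or piperazin-1-yl, or for a carboxylic acid or a longer chain carrying the amine. They also leave open whether 4-methylpiperidin-1-yl behaves alike with chloro on the aromatic carbon, as in compound 1, and whether the 4-methyl group itself matters, which piperidin-1-yl would test.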